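Trimming a Sulfonyl Substituent: Dimethylsulfamoyl to Methylsulfonyl

This account rests on a few compounds, and the source may have more. Where it says the series, first, only, none or still open, it means among the compounds named here.

The measured compounds and their values in a functional assay on the whole organism with Rattus norvegicus as the target; on this read-out lower numbers stand for an effect already at smaller amounts and higher numbers for an effect only at larger amounts of compound:
Compound 1, `C#CCn1c(=N)sc2cc(OC(F)(F)F)ccc21`, gives 4 mg/kg.
Compound 2, `COC(=O)Cn1c(=N)sc2cc(OC(F)(F)F)ccc21`, reaches only the limit of > 10 mg/kg.
Compound 3, `CN(C)S(=O)(=O)CCn1c(=N)sc2cc(OC(F)(F)F)ccc21`, likewise reaches only the limit of > 10 mg/kg.

Compound 3 therefore has no measured number, only a limit; it shares this with compound 2, as the limit of > 10 mg/kg in this assay, at which 2 of the 3 values shown sit, records. Compound 4, `CS(=O)(=O)CCn1c(=N)sc2cc(OC(F)(F)F)ccc21`, differs from compound 3 at the sulfonyl sulfur: methyl in place of dimethylamino on a sulfonyl sulfur. Among the compounds with values here, no measured step touches this sulfur. The steps that exist show an at least 2.5-fold higher number from compound 1 to compound 3 (0.39 log units; beyond the scatter) and a step that the two limits leave unreadable from compound 2 to compound 3, so the shape of this chain end is not mapped. Compound 4 is expected to stay near the limit, estimated at 12 mg/kg with a range from 5 mg/kg to 30 mg/kg. The expected step is a step that the limit leaves unreadable from compound 3 to compound 4, within the scatter.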

Compound 4, dose for half-maximal effect: 1.8 mg/kg
Beside the measured number, compound 4's estimate is 6.7-fold (0.82 log units) above it; measured number outside the range, below it.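

In this assay the sulfonyl sulfur proves to be a sensitive place: methyl in place of dimethylamino gives an at least 5.5-fold lower number from compound 3 to compound 4 (0.74 log units; beyond the scatter) and lifts the chain end clear of the limit. The (methylsulfonyl)methyl end also outdoes methoxycarbonyl, with an at least 5.5-fold lower number from compound 2 to compound 4 (0.74 log units; beyond the scatter) as the change, and it outdoes ethynyl, with a 2.2-fold lower number from compound 1 to compound 4 (0.35 log units; beyond the scatter) as a smaller but still real change. Nothing shown explains why this group performs so differently. From the compounds shown here alone, whether an ethyl or a cyclopropyl group on the sulfur would keep this gain remains open. So does the effect of a longer chain between the sulfonyl sulfur and the core.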